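The compounds below may be only part of what the source reports. "The series", "measured", "known", "first", "only" and "open" are said of these compounds alone.

In a functional assay on MDA-MB-231 cells (Homo sapiens) for antiproliferative activity, read by MTT assay, with a stated time of 72 h (on this read-out lower numbers stand for stronger inhibition and higher numbers for weaker inhibition), compound 1 `COc1cccc(-c2cccc(NC(=O)CCc3cccc4c3COB4O)c2)c1` gives 76000 nM, compound 2 `COc1cc(OC)cc(-c2cccc(NC(=O)CCc3cccc4c3COB4O)c2)c1` gives 93000 nM and compound 3 `CC(=O)c1ccc(-c2cccc(NC(=O)CCc3cccc4c3COB4O)c2)cc1` gives 41000 nM. The steps among them are small: a 1.2-fold higher number from compound 1 to compound 2 (0.09 log units; within the scatter), a 1.9-fold lower number from compound 1 to compound 3 (0.27 log units; within the scatter) and a 2.3-fold lower number from compound 2 to compound 3 (0.36 log units; beyond the scatter). Compound 3 therefore stands modestly apart from compound 2 only. Compound 4 `CC(=O)c1ccc(-c2cccc(NC(=O)CCc3cccc4c3C(O)OC4)c2)cc1` differs from compound 3 by a group of 10 heavy atoms (8 carbon, 2 oxygen; one five-membered non-aromatic ring with 1 hetero atom, one six-membered aromatic ring of carbon only) in place of a group of 10 heavy atoms (7 carbon, 1 boron, 2 oxygen; one five-membered non-aromatic ring with 2 hetero atoms, one six-membered aromatic ring of carbon only), on a saturated chain carbon, two bonds along the chain from a carbonyl carbon, and this removes the boron. The measured steps alter only the methoxy and acetyl groups, and every measured compound keeps its boron, so they offer a sense of scale but no direction for this change. A tentative step of similar size is expected, a 1.7-fold higher number from compound 3 to compound 4 (0.23 log units; within the scatter). Compound 4 is estimated at 70000 nM, with an expected range of 25000 nM to 200000 nM.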

Compound 4, half-maximal inhibitory concentration: 29000 nM
Compound 4: middle estimate off by 2.4-fold (0.38 log units), on the high side, and the stated range covers the measured number.
By their numbers in this assay, from the lowest: compounds 4, 3, 1 and 2 (each within the scatter of the next, the first and the last beyond it).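

Replacing the boron-containing ring group with the boron-free one on this saturated chain carbon gives a 1.4-fold lower number from compound 3 to compound 4 (0.15 log units; within the scatter) in this assay. For this pair, then, losing the boron leaves the number within the usual scatter, so this antiproliferative read-out does not depend on boron here. Nothing available explains this result.

Still open, on these data alone, is whether the same change would give so small a step in compound 1 or compound 2, which carry methoxy groups. Also open, as far as these compounds go, is how an amine in place of the ring hydroxyl, or a longer chain, would shift the number.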